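The source may report more compounds than this note shows. Statements on the series, on what has been measured and on what is new or still open speak of the compounds shown alone.

Going by the values given here, in an ADME assay on microsomes from liver (Mus musculus) for metabolic stability, read by LC-MS, with a stated time of 10 min (on this read-out lower numbers stand for a less stable compound and higher numbers for a more stable compound), compound 1 (`C[C@@H]1CN(c2cccc3c2C[C@H](CN(C)[C@H]2CCCc4cccnc42)NC3)C[C@H](C)N1`) gives 85.6% and compound 2 (`CN(C[C@H]1Cc2c(cccc2N2CCN3CCC[C@@H]3C2)CN1)[C@H]1CCCc2cccnc21`) gives 36.7%, so compound 2 holds the lower of the only two numbers available. Compound 3 (`CN(C[C@H]1Cc2c(cccc2N2C[C@H]3C[C@@H]2CN3)CN1)[C@H]1CCCc2cccnc21`) has not been measured yet. It differs from compound 2 by one group on an aromatic carbon: a group of 7 heavy atoms (5 carbon, 2 nitrogen; 2 five-membered non-aromatic rings with 1 hetero atom each) in place of a group of 9 heavy atoms (7 carbon, 2 nitrogen; one five-membered non-aromatic ring with 1 hetero atom, one six-membered non-aromatic ring with 2 hetero atoms), on an aromatic carbon. Among the compounds with values here, the only measured step that bears on this is a number 48.9 percentage points lower from compound 1 to compound 2 (beyond the scatter), a large change beyond the usual scatter. Within the data shown here, the group it introduces is the one that compound 3 lacks. A single step is thin evidence, but a partial recovery towards compound 1 seems the likeliest result, so a large rise is expected. The expected step is a number 25.3 percentage points higher from compound 2 to compound 3 (beyond the scatter). For compound 3 the estimated value is 62%, with an expected range from 35% to 88%.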

Compound 3, percent of the compound remaining: 95.9%
Compound 3: middle estimate off by 33.9 percentage points, on the low side; the whole stated range lies below it.
By their numbers in this assay, from the lowest: compound 2; then compound 1; then compound 3.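

The group on this aromatic carbon can raise stability as well as lower it. In this assay, changing to the group with 2 five-membered non-aromatic rings gives a number 59.2 percentage points higher from compound 2 to compound 3 (beyond the scatter) and so more than reverses the earlier loss. The same group also gives a number 10.3 percentage points higher from compound 1 to compound 3 (beyond the scatter) and shows that this position can do better than the dimethyl-substituted six-membered ring group, while no available evidence explains why these groups behave so differently.

Three compounds are too few to link stability to ring size or shape, especially as the highest and lowest values both come from groups with a five-membered ring. From the compounds shown here alone, it remains open whether a morpholine or an unsubstituted piperazine on this carbon would sit near compound 3 or fall towards compound 2.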